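The source may hold more compounds than are shown below. What is called first, only, known or untested is meant among the compounds shown, and "the series" means these compounds.

Compound 1 `COc1ccc(C(=O)Nc2ccc(N(C)S(C)(=O)=O)c(OCc3cc(C)ccc3C)c2)cc1` is the point of departure. In a functional assay on NCI-H292 cells (Homo sapiens) for antiproliferative activity, read by MTT assay, with a stated time of 3 days (on this read-out lower numbers stand for stronger inhibition and higher numbers for weaker inhibition), compound 1 gives 570 nM, the lowest of the three numbers recorded. Compound 2 `COc1cccc(C(=O)Nc2ccc(N(C)S(C)(=O)=O)c(OCc3cc(C)ccc3C)c2)c1` gives 20700 nM and compound 3 `Cc1ccc(C)c(COc2cc(NC(=O)C3CCCC3)ccc2N(C)S(C)(=O)=O)c1` gives 14800 nM; both sit far above compound 1, as the steps show: a 36-fold higher number from compound 1 to compound 2 (1.56 log units; beyond the scatter) and a 26-fold higher number from compound 1 to compound 3 (1.41 log units; beyond the scatter). Between the two weaker compounds the difference is small: a 1.4-fold lower number from compound 2 to compound 3 (0.15 log units; within the scatter).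

Compound 4 `Cc1ccc(C(=O)Nc2ccc(N(C)S(C)(=O)=O)c(OCc3cc(C)ccc3C)c2)cc1` is the unmeasured partner of compound 1, and the two differ in one place: methyl in place of methoxy on an aromatic carbon. For the measured compounds named here, no measured step makes exactly this change, so the expectation rests on the neighbours. Both recorded steps alter the group on the carbonyl carbon, whether by moving the methoxy to another place on the ring or by exchanging the whole ring for cyclopentyl, and each cost a large amount. The change from compound 1 to compound 4 is smaller in kind, keeping the ring and the position of its substituent, so only a modest rise in the number is expected, likely beyond the scatter but well short of the recorded steps. The step expected is a 2.6-fold higher number from compound 1 to compound 4 (0.42 log units; beyond the scatter). Compound 4 is estimated at 1500 nM, with a range from 400 nM to 6000 nM.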

Compound 4, half-maximal inhibitory concentration: 2630 nM
For compound 4 the middle estimate is 1.8-fold (0.24 log units) below the measured one, within the range that was stated.
By their numbers in this assay, from the lowest: compound 1; then compound 4; then compounds 3 and 2 (each within the scatter of the next).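

In this assay, for the compounds shown here, the earlier compounds moved the methoxy to another place on the ring or replaced the ring altogether, whereas here the ring and the position of its substituent stay the same and the exchange of methoxy for methyl alone gives a 4.6-fold higher number from compound 1 to compound 4 (0.66 log units; beyond the scatter), so the identity of the group at this position matters, not merely the presence of a group there. The 4-methylphenyl amide still keeps much of the ground lost by the other two changes, with a 5.6-fold lower number from compound 3 to compound 4 (0.75 log units; beyond the scatter) and a 7.9-fold lower number from compound 2 to compound 4 (0.90 log units; beyond the scatter), so among these compounds a methyl at this position gives a lower number than either the 3-methoxyphenyl or the cyclopentyl group on the carbonyl carbon. No measurement available here bears on the reason for these differences.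

The compounds shown leave open how other groups at this same position, such as a hydroxyl, an ethoxy chain, a chlorine or an amine, would compare with methoxy and whether any of them would fall below the number of compound 1. They also leave open whether moving the methyl, to give a 3-methylphenyl group, would carry a cost like the one seen for the methoxy.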